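The source may report more compounds than this note shows. Statements on the series, on what has been measured and on what is new or still open speak of the compounds shown alone.

Compound 1 `COc1ccc(-c2nc(SCC(=O)c3sc(-c4ccccc4)nc3C)[nH]c(=O)c2C#N)cc1`: 48400 nM
Compound 2 `COc1ccc(-c2nc(C)c(C(=O)CSc3nc(N)c(C#N)c(-c4ccccc4)n3)s2)cc1`: 8540 nM
Compound 3 `COc1ccc(-c2nc(SCC(=O)c3sc(-c4ccc(Cl)cc4)nc3C)[nH]c(=O)c2C#N)cc1`: 35500 nM

All three values come from a functional assay on U-87MG ATCC cells for antiproliferative activity against U-87 MG (Homo sapiens), read by MTT assay, with a stated time of 48 h; on this read-out lower numbers stand for stronger inhibition and higher numbers for weaker inhibition. Compound 1 and compound 3 lie within the scatter of each other at the high end of this small set, and compound 2 gives a clearly lower number than either.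

The next compound is compound 4 `Cc1nc(-c2ccccc2)sc1C(=O)CSc1nc(-c2ccc(Cl)cc2)c(C#N)c(=O)[nH]1`, which keeps the core of compound 1. The change is chloro in place of methoxy on an aromatic carbon, or 4-methoxyphenyl to 4-chlorophenyl.

For the measured compounds named here, one measured step bears on this: a 1.4-fold lower number from compound 1 to compound 3 (0.13 log units; within the scatter). It is chloro in place of hydrogen on an aromatic carbon, at a different place in the molecule, so it is only an indirect guide. Compound 2 differs from compound 1 in more than one place and does not isolate this change. Going by the values given here, no measured step shows methoxy leaving.

Among the compounds with values here, with only that small step to go on, no change beyond the scatter is expected, and no direction can be assigned with confidence. The expected step is a 1.2-fold lower number from compound 1 to compound 4 (0.06 log units; within the scatter). For compound 4 the estimated value is 42000 nM, with an expected range of 16000 nM to 110000 nM.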

Compound 4, half-maximal inhibitory concentration: 43400 nM
Compound 4: middle estimate off by 1.0-fold (0.01 log units), on the low side; the range from low to high includes it.
By their numbers in this assay, from the lowest: compound 2; then compounds 3, 4 and 1 (each within the scatter of the next).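

In this assay, 4-methoxyphenyl to 4-chlorophenyl on the core of compound 1 gives a 1.1-fold lower number from compound 1 to compound 4 (0.05 log units; within the scatter) and is the only measured step at this position among the compounds shown. For the compounds shown here, the earlier chloro step lay at a different place in the molecule, so this result is the first direct reading of methoxy leaving and chloro entering on an aromatic carbon para to a large group. Here, replacing methoxy and its hydrogen-bond acceptor with chloro leaves the number within the scatter, so this single pair shows no measurable gain or loss from the change, and no measurement at hand offers an explanation for that.

A single pair cannot show whether the position is insensitive in general, and an amine or a carboxylic acid on the same phenyl ring could still give a number beyond the scatter of compound 1. From the compounds shown here alone, it also remains open whether the same exchange would stay within the scatter on the background of compound 3, which already carries chloro at the other place.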